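Methyl to trifluoromethyl: expected clearance of compound 3

The compounds below may be only part of what the source reports. "The series", "measured", "known", "first", "only" and "open" are said of these compounds alone.

- Compound 1 `Cc1ccc(Cn2c(=O)[nH]c3c(N)nc(C(F)(F)F)cc32)cn1`: < 7 mL.min-1.g-1
- Compound 2 `Cc1ccc(Cn2c(=O)[nH]c3c(N)nc(C(F)(F)F)cc32)nn1`: < 8 mL.min-1.g-1

In an in vitro ADME assay on microsomes from liver (Homo sapiens) for metabolic stability (a higher number here means faster removal of the compound, a lower number slower removal), compound 1 stands only at a limit (< 7 mL.min-1.g-1) and has no exact number. Compound 2 is also only a limit (< 8 mL.min-1.g-1) in this assay here.

Compound 3 `Nc1nc(C(F)(F)F)cc2c1[nH]c(=O)n2Cc1ccc(C(F)(F)F)nc1` carries trifluoromethyl in place of the methyl of compound 1 on an aromatic carbon (trifluoromethyl in place of methyl on an aromatic carbon) next to the ring nitrogen and para to a large group.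

For the measured compounds named here, the one measured step is a step that the two limits leave unreadable from compound 1 to compound 2 and it leaves the methyl in place, so no measured step gives a size for this change. Little or no step beyond the scatter is therefore expected, and a small move towards faster removal is the expected direction. The expected step is an at least 1.1-fold higher number from compound 1 to compound 3 (0.05 log units; that floor lies within the scatter) and it remains a loose estimate. Compound 3 is estimated at 8 mL.min-1.g-1 (expected range 5 mL.min-1.g-1 to 16 mL.min-1.g-1) in this assay and may again be reported only as a limit.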

Compound 3, intrinsic clearance in microsomes: < 7 mL.min-1.g-1
Compound 3: a limit, no number (the forecaster's own chance of this, stated with the estimate: 55%); middle value at least 1.1-fold (0.05 log units) from the limit.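

Compound 3 gives only a limit, < 7 mL.min-1.g-1. For the compounds shown here, compound 1 is also a limit, and no step between compound 1 and compound 3 can be read. The compounds shown leave open whether trifluoromethyl in place of methyl on an aromatic carbon changes the result in this assay at all.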